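Swapping Phenyl for Ethoxy on a Carbonyl Carbon

The source may report more compounds than this note shows. Statements on the series, on what has been measured and on what is new or still open speak of the compounds shown alone.

In a functional assay on HepG2 cells (Homo sapiens) for inhibition, read by MTT assay, with a stated time of 48 h (on this read-out higher numbers stand for weaker inhibition and lower numbers for stronger inhibition), compound 1 `COc1ccc(CSc2nnc(-c3cc(OC)c(OC)c(OC)c3)n2-c2ccc(N(C)C)cc2)cc1` gives > 60000 nM, which is a limit of the assay and not a number. Going by the values given here, compound 2 `COc1cc(-c2nnc(SCC(=O)c3ccccc3)n2-c2ccc(N(C)C)cc2)cc(OC)c1OC`, at 18900 nM, holds the only true number so far. Among the compounds with values here, the one measured step, an at least 3.1-fold lower number from compound 1 to compound 2 (0.50 log units; beyond the scatter), put benzoyl in place of 4-methoxyphenyl, and its size rests on (the limit of > 60000 nM in this assay, at which 1 of the 2 values shown sits). Compound 3 `CCOC(=O)CSc1nnc(-c2cc(OC)c(OC)c(OC)c2)n1-c1ccc(N(C)C)cc1` carries ethoxy in place of phenyl on a carbonyl carbon. Only compound 2 at 18900 nM and that single step guide the expectation. A small step in this assay, leaning towards weaker inhibition, is expected: a 1.6-fold higher number from compound 2 to compound 3 (0.20 log units; within the scatter). Compound 3 is estimated at 30000 nM, with a range of 12000 nM to 80000 nM.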

Compound 3, half-maximal inhibitory concentration: > 60000 nM
Compound 3: a limit, no number; the forecaster's own chance of this, stated with the estimate: 35%; middle value at least 2.0-fold (0.30 log units) from the limit.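

Ethoxy does not stand in for phenyl on this carbonyl carbon in this assay, where the change gives an at least 3.1-fold higher number from compound 2 to compound 3 (0.50 log units; beyond the scatter). Among the groups shown on this chain, only benzoyl gives a true number, and the size of the step is only a minimum: the limit of > 60000 nM in this assay, at which 2 of the 3 values shown sit. The remaining step, between compound 1 and compound 3, cannot be read, as both values are limits.

From the compounds shown here alone, it remains open whether the ring itself matters on this carbonyl carbon. A methyl group, an amide nitrogen or a 4-chlorophenyl ring there could help to settle this.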